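Shortening the Ester Chain on a Tyrosol Phenol

This account rests on a few compounds, and the source may have more. Where it says the series, first, only, none or still open, it means among the compounds named here.

Compound 1, `CCCCCCCCCCCC(=O)OCCc1ccc(O)cc1`: 67200 nM
Compound 3, `CCCCCCCCCCCC(=O)OCCc1ccc(O)c(O)c1`: 38100 nM
Compound 2, `CC(=O)OCCc1ccc(O)c(O)c1`: > 50000 nM, a limit of the assay rather than a number

All of these come from a toxicity assay on MRC5 cells (Homo sapiens) for inhibition, read by MTT assay, with a stated time of 72 h; on this read-out higher numbers stand for weaker inhibition and lower numbers for stronger inhibition. Of the two numbers shown, compound 1 has the highest; compound 3 is nearest, at a 1.8-fold lower number from compound 1 to compound 3 (0.25 log units; within the scatter), which is within the scatter. The value of compound 2 is a limit of the assay, not a number, as shown by the limit of > 50000 nM in this assay, at which 1 of the 3 values shown sits.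

The piece follows the step to compound 4, `CCCCCC(=O)OCCc1ccc(O)cc1`, which differs from compound 1 in one place: hydrogen in place of hexyl on a saturated chain carbon, five bonds along the chain from a carbonyl carbon. Among the compounds with values here, no measured step changes the length of this chain. Within the data shown here, the only measured step, a 1.8-fold lower number from compound 1 to compound 3 (0.25 log units; within the scatter), concerns a hydroxy group and does not bear on it. What can be said comes from two values on the other core: compound 3, carrying the long chain, gives 38100 nM. Compound 2, carrying a shorter chain on that same core, gives only a limit of the assay, > 50000 nM.

On that basis the shorter chain in compound 4 is expected to give a higher number than compound 1, with a real chance that this assay reports only a limit. Compound 4 is therefore estimated at 100000 nM, between 45000 nM and 250000 nM. The expected step is a 1.5-fold higher number from compound 1 to compound 4 (0.17 log units; within the scatter).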

Compound 4, half-maximal inhibitory concentration: 166000 nM
Compound 4: middle estimate off by 1.7-fold (0.22 log units), on the low side; low and high end bracket the measured number.
By their numbers in this assay, from the lowest: compounds 3 and 1 (each within the scatter of the next); then compound 4.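

In this assay, removing the hexyl group from the ester chain gives a 2.5-fold higher number from compound 1 to compound 4 (0.39 log units; beyond the scatter). This is the first change at this position among the compounds shown. Higher numbers stand for weaker inhibition here: compound 4, with the shorter chain, inhibits these cells less than compound 1 does. The hydroxy step on the ring stayed within the scatter, so this change in the chain is the first shown to move the number by more than repeated measurements would.

On the other core, compound 2 gives only a limit, so the size of a similar shortening there cannot be read: the limit of > 50000 nM in this assay, at which 1 of the 4 values shown sits.

Going by these compounds, with only compound 1 and compound 4 to compare on this core, the shape of the relationship between chain and toxicity stays open, including whether a longer chain, a chain of intermediate length, or a chain ending in an amine or a carboxylic acid would follow the same direction.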